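A few compounds are considered here, and "the series" means these few. Any claim that something is new, unique, unknown or untested is made for them only; others in the source may bear on it.

Compound 1 `O=C1/C(=C/c2cccc(Cl)c2)Cc2ccccc21`: 41200 nM in a functional assay on L1210 cells (Mus musculus) for inhibition; on this read-out lower numbers stand for stronger inhibition and higher numbers for weaker inhibition
Compound 2 `O=C1/C(=C/c2cccc(Br)c2)Cc2ccccc21`: 43300 nM in this assay
Compound 3 `O=C1/C(=C/c2cccc(Cl)c2)CCCc2ccccc21`: 52300 nM in this assay

Compound 1 and compound 2 share one core and differ only by bromo in place of chloro on an aromatic carbon. In this assay this change gave a 1.1-fold higher number from compound 1 to compound 2 (0.02 log units; within the scatter), so the two values are indistinguishable within the scatter. Compound 3 carries a different core; the difference between the two cores is not broken down here, and its value sits within the scatter of both compound 1 and compound 2.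

Compound 4 `O=C1/C(=C/c2cccc(Br)c2)CCCc2ccccc21` is not yet measured. It relates to compound 3 by bromo in place of chloro on an aromatic carbon, the same change as that between compound 1 and compound 2, at the same place. Because that change gave a 1.1-fold higher number from compound 1 to compound 2 (0.02 log units; within the scatter), the step is expected to be a 1.1-fold higher number from compound 3 to compound 4 (0.03 log units; within the scatter). Compound 4 is therefore estimated at 56000 nM in this assay, with a range from 30000 nM to 110000 nM.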

Compound 4, half-maximal inhibitory concentration: 51000 nM
Compound 4: middle estimate off by 1.1-fold (0.04 log units), on the high side, and the stated range covers the measured number.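

In this assay, bromo in place of chloro on an aromatic carbon gave a 1.0-fold lower number from compound 3 to compound 4 (0.01 log units; within the scatter). Set beside the earlier step, the change reads the same on both cores: the same change on two cores in this assay, a 1.1-fold higher number (0.02 log units; within the scatter) from compound 1 to compound 2 and a 1.0-fold lower number (0.01 log units; within the scatter) from compound 3 to compound 4, 1.1-fold (0.03 log units) apart, within the scatter of two such steps. This shows that the swap between these two groups carries from one core to the other without a detectable difference, but both steps stay within the scatter, so it is a weak test of transfer and says nothing about a change with a larger step or about other cores.

The compounds shown leave open whether an amine or a methoxy group on the same aromatic carbon would shift the number on either core. They also leave open what the difference between the two cores contributes on its own.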